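Replacing 4-fluorophenyl with 3-methoxyphenyl on a carbonyl carbon

This account rests on a few compounds, and the source may have more. Where it says the series, first, only, none or still open, it means among the compounds named here.

Compound 1 `CCCCc1ccc2[nH]c(-c3ccc(OC)cc3)c(/C=N/NC(=O)c3ccccc3)c2c1`: 32 nM
Compound 2 `CCCCc1ccc2[nH]c(-c3ccc(OC)cc3)c(/C=N/NC(=O)c3ccc(Cl)cc3)c2c1`: 90 nM
Compound 3 `CCCCc1ccc2[nH]c(-c3ccc(OC)cc3)c(/C=N/NC(=O)c3ccc(F)cc3)c2c1`: 19 nM

In a functional assay on MDA-MB-231 cells (Homo sapiens) for antiproliferative activity, with a stated time of 4 days (a higher number here means a weaker inhibitor, a lower number a stronger inhibitor), compound 3 shares the low end of this small set with compound 1. There is a 1.7-fold lower number from compound 1 to compound 3 (0.23 log units; within the scatter), so the two cannot be separated. Compound 2 stands apart, with a 2.8-fold higher number from compound 1 to compound 2 (0.45 log units; beyond the scatter) and a 4.7-fold lower number from compound 2 to compound 3 (0.68 log units; beyond the scatter).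

Compound 4 `CCCCc1ccc2[nH]c(-c3ccc(OC)cc3)c(/C=N/NC(=O)c3cccc(OC)c3)c2c1` has not yet been measured. Its difference from compound 3 is 3-methoxyphenyl in place of 4-fluorophenyl on a carbonyl carbon. In words, it has 3-methoxyphenyl in place of 4-fluorophenyl on a carbonyl carbon, while the rest of the molecule stays the same.

Within the data shown here, no measured compound carries 3-methoxyphenyl at that place, so the evidence is indirect. The three measured steps all change the same aromatic ring, and the widest of them is still only modest: a 4.7-fold lower number from compound 2 to compound 3 (0.68 log units; beyond the scatter). A modest step is therefore expected here too, and upward is the likelier direction, given that compound 3 sits at the low end with 19 nM. The expected change in this assay is a 2.4-fold higher number from compound 3 to compound 4 (0.37 log units; beyond the scatter). For compound 4 the estimated value is 45 nM, with an expected range of 15 nM to 130 nM.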

Compound 4, half-maximal inhibitory concentration: 55 nM
For compound 4 the middle estimate is 1.2-fold (0.09 log units) below the measured one; the range from low to high includes it.
By their numbers in this assay, from the lowest: compounds 3, 1, 4 and 2 (each within the scatter of the next, the first and the last beyond it).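

In this assay, among these compounds, compound 4 shows that a 3-methoxyphenyl group, which brings 1 hydrogen-bond acceptor where 4-fluorophenyl has none, can stand on this carbonyl carbon at a modest cost, with a 2.9-fold higher number from compound 3 to compound 4 (0.46 log units; beyond the scatter) as the only new step beyond the scatter. The other two new steps separate nothing: a 1.7-fold higher number from compound 1 to compound 4 (0.24 log units; within the scatter) and a 1.6-fold lower number from compound 2 to compound 4 (0.21 log units; within the scatter) both lie within the scatter. This change therefore sets compound 4 apart from the 4-fluorophenyl compound alone, while the data give no clear difference between 3-methoxyphenyl and either plain phenyl or 4-chlorophenyl at this place. Nothing among the measurements shown accounts for these steps.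

The compounds shown leave open whether the step to compound 4 follows from the methoxy group itself or from where it sits on the ring, since a 4-methoxyphenyl group is not among them to separate the two. They also leave open how this place responds to groups of another kind, such as an aminophenyl group or a carboxylic acid on the same ring.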